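The source may hold more compounds than are shown below. What is called first, only, known or untested is meant among the compounds shown, and "the series" means these compounds.

Compound 1 `N#CC1=C(N)Oc2c(c3nc4ccccc4nc3c3ccccc23)C12C(=O)N(Cc1cnnn1-c1ccccc1Cl)c1ccccc12` and compound 2 `CCc1ccccc1-n1nncc1CN1C(=O)C2(C(C#N)=C(N)Oc3c(N)cc4nc5ccccc5nc4c32)c2ccccc21` share one core and differ in the groups around it. In an ADME assay on L02 cells (Homo sapiens) for antiproliferative activity, read by MTT assay, with a stated time of 48 h (on this read-out higher numbers stand for weaker inhibition and lower numbers for stronger inhibition), compound 1 gives only a limit, > 50000 nM. Compound 2 gives the single number shown in this assay, 22900 nM, which places it as the one compound with a measured value. The other value, that of compound 1, is a limit: the limit of > 50000 nM in this assay, at which 1 of the 2 values shown sits. Compound 3 `N#CC1=C(N)Oc2c(N)cc3nc4ccccc4nc3c2C12C(=O)N(Cc1cnnn1-c1ccc(F)c(Cl)c1)c1ccccc12` has not been measured in this assay. It differs from compound 2 in one place: 3-chloro-4-fluorophenyl in place of 2-ethylphenyl on an aromatic nitrogen Since no step between measured compounds is shown, there is nothing to set the size of this change against. Compound 3 is expected to stay near compound 2, with a step of a 1.1-fold higher number from compound 2 to compound 3 (0.04 log units; within the scatter) in this assay that lies within the scatter, or perhaps slightly weaker inhibition. Compound 3 is thus estimated at 25000 nM in this assay, between 8000 nM and 50000 nM.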

Compound 3, half-maximal inhibitory concentration: > 50000 nM
Compound 3 gave a limit, no number; the forecaster's own chance of this, stated with the estimate: 35%; middle value at least 2.0-fold (0.30 log units) from the limit.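

Among the compounds shown here, on the aromatic nitrogen of the five-membered ring, 3-chloro-4-fluorophenyl in place of 2-ethylphenyl gives an at least 2.1-fold higher number from compound 2 to compound 3 (0.33 log units; beyond the scatter) in this assay, the only step at this position that can be read. The position is therefore not indifferent to which substituted phenyl it carries, although both groups have the same heavy-atom count and neither has a hydrogen-bond donor or acceptor. Compound 3 gives only a limit and not a number, and it now stands with compound 1 at that limit: the limit of > 50000 nM in this assay, at which 2 of the 3 values shown sit.

The true size of the step stays open, and the compounds shown do not separate the loss of the ethyl group from the arrival of chlorine and fluorine. Also open, from the compounds shown here alone, is how a phenyl ring carrying an amine or a carboxylic acid at this position would read in this assay.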